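Triazole carboxamides against HT-29 cells: methyl to trifluoromethyl

A few compounds are considered here, and "the series" means these few. Any claim that something is new, unique, unknown or untested is made for them only; others in the source may bear on it.

Measured compounds:
compound 1 `Cc1c(C(=O)Nc2ccc(Oc3ccnc4[nH]ccc34)c(F)c2)nnn1-c1ccc(F)c(F)c1` gives 610 nM
compound 2 `Cc1c(C(=O)Nc2ccc(Oc3ccnc4[nH]ccc34)cc2)nnn1-c1ccccc1F` gives 360 nM
compound 3 `O=C(Nc1ccc(Oc2ccnc3[nH]ccc23)c(F)c1)c1nnn(-c2ccc(F)c(F)c2)c1C(F)(F)F` gives 320 nM

The three measured compounds were tested in a functional assay on HT-29 cells (Homo sapiens) for cytotoxicity, read by MTT assay, with a stated time of 72 h; a higher number here means a weaker inhibitor, a lower number a stronger inhibitor. Compound 1 gives 610 nM, compound 2 gives 360 nM and compound 3 gives 320 nM. All three numbers lie within the usual scatter of one another, so no ordering among them is claimed.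

Compound 1 and compound 3 differ in one place, described here: trifluoromethyl in place of methyl on an aromatic carbon. This change made the step of a 1.9-fold lower number from compound 1 to compound 3 (0.28 log units; within the scatter).

Compound 4 `O=C(Nc1ccc(Oc2ccnc3[nH]ccc23)cc1)c1nnn(-c2ccccc2F)c1C(F)(F)F` has not yet been measured in this assay. It relates to compound 2 by a change of the same kind, described here: trifluoromethyl in place of methyl on an aromatic carbon. The two changes are the same kind, not the same: in compound 1 the altered ring atom sits next to the ring atom that bears a 3,4-difluorophenyl group, whereas in compound 2 it sits next to the ring atom that bears a 2-fluorophenyl group. How the cores of compound 1 and compound 2 differ beyond this is not broken down here.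

Going by the values given here, for compound 4 the step from compound 2 is expected to resemble the earlier one, that is a 1.6-fold lower number from compound 2 to compound 4 (0.21 log units; within the scatter), because the only precedent is a 1.9-fold lower number from compound 1 to compound 3 (0.28 log units; within the scatter), which itself lies within the scatter. Compound 4 is therefore estimated at 220 nM, with a plausible range from 100 nM to 500 nM.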

Compound 4, half-maximal inhibitory concentration: 120 nM
Beside the measured number, compound 4's estimate is 1.8-fold (0.26 log units) above it, and the stated range covers the measured number.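

In this assay, going by these compounds alone, placing trifluoromethyl instead of methyl on the aromatic carbon of the triazole gave a 3.0-fold lower number from compound 2 to compound 4 (0.48 log units; beyond the scatter), a modest step and the first reading of this change that stands clear of the scatter. Set beside the earlier step, the change points the same way on both cores, and the two sizes cannot be told apart, so the data give no sign that the core of compound 2 responds differently from the core of compound 1: the same change on two cores in this assay, a 1.9-fold lower number (0.28 log units; within the scatter) from compound 1 to compound 3 and a 3.0-fold lower number (0.48 log units; beyond the scatter) from compound 2 to compound 4, 1.6-fold (0.20 log units) apart, within the scatter of two such steps. This supports carrying the change between these two cores only with caution, since just one of the two steps lies beyond the scatter, and it shows neither that the change would hold on a further core nor why the number falls.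

The compounds shown leave open how other groups on that aromatic carbon, such as ethyl, cyclopropyl, a nitrile or an amine, would read in this assay. They also leave open whether the step persists when the 2-fluorophenyl group gives way to an unsubstituted phenyl group or to a pyridine ring.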